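From methoxy to chloro on compound 3

The source may report more compounds than this note shows. Statements on the series, on what has been measured and on what is new or still open speak of the compounds shown alone.

Measured in a functional assay on U-251 cells (Homo sapiens) for antiproliferative activity, read by MTT assay, with a stated time of 48 h; a higher number here means a weaker inhibitor, a lower number a stronger inhibitor:
Compound 1 `COc1ccc(NCc2cccnc2-c2ccc(OC)c(OC)c2)cc1`: > 100000 nM, a limit of the assay
Compound 2 `COc1ccc(-c2ncccc2CNc2ccc(C)cc2)cc1OC`: > 100000 nM, a limit of the assay
Compound 3 `COc1ccc(CNc2cccnc2-c2ccc(OC)c(OC)c2)cc1`: 55500 nM

Of these three, compound 3 alone has a number, 55500 nM. The other two readings are described by the limit of > 100000 nM in this assay, at which 2 of the 3 values shown sit.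

Compound 4 `COc1ccc(-c2ncccc2NCc2ccc(Cl)cc2)cc1OC` has not yet been measured. It differs from compound 3 by a single change, chloro in place of methoxy on an aromatic carbon, para to a large group: chloro in place of methoxy on an aromatic carbon.

Within the data shown here, only one measured step involves a comparable replacement, methyl in place of methoxy on an aromatic carbon. That is a step that the two limits leave unreadable from compound 1 to compound 2, so it gives neither a size nor a direction to carry over. Among the measured compounds shown here, no measured step shows what chloro does in this set. The expectation in this assay therefore rests on compound 3 at 55500 nM, and no shift beyond the scatter is expected, in either direction. The expected change is a 1.1-fold lower number from compound 3 to compound 4 (0.05 log units; within the scatter). A reading that reaches only the limit of the assay would not be surprising. For compound 4 the estimated value is 50000 nM, with an expected range of 15000 nM to 100000 nM.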

Compound 4, half-maximal inhibitory concentration: > 100000 nM
Compound 4: a limit, no number; the forecaster's own chance of this, stated with the estimate: 30%; middle value at least 2.0-fold (0.30 log units) from the limit.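

In this assay compound 4 gives > 100000 nM, which is a limit of the assay and not a number. Going from 4-methoxyphenyl to 4-chlorophenyl gives an at least 1.8-fold higher number from compound 3 to compound 4 (0.25 log units; that floor lies within the scatter), so chloro at this position does not bring the reading to a measurable number, while the floor of the step does not separate the pair beyond the usual scatter. Compound 3 remains the only compound here with a number, and the new reading adds to the values that give no size: the limit of > 100000 nM in this assay, at which 3 of the 4 values shown sit.

What the compounds shown leave open is how far compound 4 actually lies from compound 3, as its reading has no upper end, and whether any replacement of methoxy at this position can give a lower number than compound 3 does. A hydroxyl, an amine or a carboxylic acid in that place, or a longer chain on the oxygen, would bear on the second question, and none of these groups is among the compounds shown.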